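Swapping Bromo for Cyano on a Weak Compound

This account rests on a few compounds, and the source may have more. Where it says the series, first, only, none or still open, it means among the compounds named here.

In a functional assay for inhibition, with Rattus norvegicus as the target (on this read-out lower numbers stand for stronger inhibition and higher numbers for weaker inhibition), compound 1 (`CC(=O)C(c1ccc(C(F)(F)F)cc1)C1C(=O)C(=O)C1NCCC(C)(C)C`) gives 16200 nM and compound 2 (`CCc1cc(C#N)ccc1Nc1c(N[C@H](C)CC(C)(C)C)c(=O)c1=O`) gives 90 nM as measured numbers. Compound 3 (`CC(C)(C)CCNC1C(=O)C(=O)/C1=C\c1ccc(Br)cc1`) has only a limit (> 30000 nM) and no number. Compound 4 (`CC(C)(C)CCNC1C(=O)C(=O)/C1=C\c1ccc(C#N)cc1`) has cyano in place of bromo on an aromatic carbon, para to a large group (cyano in place of bromo on an aromatic carbon). Among the compounds with values here, no measured pair isolates this exchange. Compound 2, which also carries cyano on a different core, reaches 90 nM and offers only a weak hint. A modest shift toward stronger inhibition is expected for the step of an at least 2.0-fold lower number from compound 3 to compound 4 (0.30 log units; that floor lies within the scatter) and another limit remains possible. In this assay compound 4 is estimated at 15000 nM with an expected range from 3000 nM to 40000 nM for the coming measurement.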

Compound 4, half-maximal inhibitory concentration: 2940 nM
Beside the measured number, compound 4's estimate is 5.1-fold (0.71 log units) above it, outside the stated range (below it).
By their numbers in this assay, from the lowest: compound 2; then compound 4; then compound 1. At a limit, above all of these: compound 3.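

In this assay, cyano in place of bromo on an aromatic carbon, para to a large group, gives an at least 10-fold lower number from compound 3 to compound 4 (1.00 log units; beyond the scatter). Within the data shown here, this shows that the read-out responds to the exchange at this position, which no earlier pair could isolate. The true size of the step remains unknown, since compound 3 carries only a limit: the limit of > 30000 nM in this assay, at which 1 of the 4 values shown sits.

On these data alone, whether an amine or a carboxylic acid at this position would give a lower or higher number remains open. So does whether the same exchange would produce a similar step on the core of compound 1.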